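Trading a Bromo-Nitrile Ring for a Chlorophenyl

The source may hold more compounds than are shown below. What is called first, only, known or untested is meant among the compounds shown, and "the series" means these compounds.

Of the compounds shown here, three sharing one core have been tested in an ADME assay on HEL cells (Homo sapiens) for cytotoxicity; a higher number here means that more compound is tolerated, a lower number that less compound is tolerated. Compound 1 `C/C(=N\NC(=O)COc1cccc2ccccc12)c1ccc(C#N)cc1Br` gives 12.7 ug/mL and stands second highest of the three. Compound 3 `O=C(COc1cccc2ccccc12)N/N=C/c1ccccc1Cl` gives 62.7 ug/mL, a higher number whose gap to compound 1 lies beyond the scatter of repeated measurements. Compound 2 `O=C(COc1cccc2ccccc12)N/N=C/c1c(O)ccc2ccccc12` gives 1.94 ug/mL, a lower number, with a gap that also lies beyond the scatter. Compound 4 `C/C(=N\NC(=O)COc1cccc2ccccc12)c1ccc(Cl)cc1` has not yet been measured in this assay. It differs from compound 1 in one place: 4-chlorophenyl in place of 2-bromo-4-cyanophenyl on a carbon with a double bond to nitrogen. Among the measured compounds shown here, no pair of measured compounds differs in just one place, so no measured step tells how such a swap moves the read-out. Compound 3 gives 62.7 ug/mL, which shows that a member of this series can reach a high number. The step of a 2.4-fold higher number from compound 1 to compound 4 (0.37 log units; beyond the scatter) is expected to be an increase of moderate size, beyond the scatter. Compound 4 is estimated at 30 ug/mL, with a range from 10 ug/mL to 90 ug/mL.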

Compound 4, half-maximal cytotoxic concentration: 7.1 ug/mL
For compound 4 the middle estimate is 4.2-fold (0.63 log units) above the measured one, outside the stated range (below it).
By their numbers in this assay, from the lowest: compound 2; then compounds 4 and 1 (each within the scatter of the next); then compound 3.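

Among the compounds shown here, replacing 2-bromo-4-cyanophenyl with 4-chlorophenyl on a carbon with a double bond to nitrogen gives a 1.8-fold lower number from compound 1 to compound 4 (0.25 log units; within the scatter) in this assay and is the first direct reading of a single change. The swap takes away the bromine and the nitrile and brings in a chlorine, yet compound 1 and compound 4 cannot be told apart, so at this place the read-out tolerates this exchange of ring substituents. Nothing measured here bears on why the two compounds match.

Still open, from the compounds shown here alone, is whether a phenyl ring carrying an amine or a carboxylic acid at this place would shift the read-out beyond the scatter. Also open, going by these compounds, is what the bromine and the nitrile each do alone, which a ring carrying just one of them would show.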